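The compounds below may be only part of what the source reports. "The series", "measured", "known", "first", "only" and "open" are said of these compounds alone.

Compound 1 `Cc1ccc(NC(=S)NC(=O)c2ccc(OCc3ccc(Cl)c(Cl)c3)cc2)cc1-c1nc2ccccc2[nH]1` and compound 2 `Cc1ccc(NC(=S)NC(=O)c2ccc(OCc3ccc(Cl)cc3Cl)cc2)cc1-c1nc2ccccc2[nH]1` share a thiourea-linked core, while compound 3 `Cc1ccc(NC(=O)NC(=O)c2ccc(OCc3ccc(Cl)c(Cl)c3)cc2)cc1-c1nc2ccccc2[nH]1` and compound 4 `Cc1ccc(NC(=O)NC(=O)c2ccc(OCc3ccc(Cl)cc3Cl)cc2)cc1-c1nc2ccccc2[nH]1` carry a urea linkage instead; how the core of compound 3 differs from the core of compound 1 is not broken down here. In a functional assay on SW-620 cells (Homo sapiens) for inhibition, read by MTT assay, with a stated time of 48 h (a lower number here means a stronger inhibitor, a higher number a weaker inhibitor), compound 1 gives 30700 nM, and compound 2 gives 57200 nM. The change between them, (2,4-dichlorophenyl in place of 3,4-dichlorophenyl on a saturated chain carbon bound to an oxygen on an aromatic ring), produced a 1.9-fold higher number from compound 1 to compound 2 (0.27 log units; within the scatter). Compound 3 gives 6100 nM, the lowest number of the three measured compounds. Within the data shown here, the change from compound 3 to compound 4, (2,4-dichlorophenyl in place of 3,4-dichlorophenyl on a saturated chain carbon bound to an oxygen on an aromatic ring), is the same change at the same place as the one from compound 1 to compound 2. On the core of compound 3 the step is therefore expected to be of similar size, a 1.6-fold higher number from compound 3 to compound 4 (0.19 log units; within the scatter), because the earlier step of a 1.9-fold higher number from compound 1 to compound 2 (0.27 log units; within the scatter) stayed within the scatter. The estimate for compound 4 in this assay is 9500 nM, with a likely range from 4000 nM to 22000 nM.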

Compound 4, half-maximal inhibitory concentration: 12200 nM
Beside the measured number, compound 4's estimate is 1.3-fold (0.11 log units) below it; measured number inside the range.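

In this assay, 2,4-dichlorophenyl in place of 3,4-dichlorophenyl gave a 2.0-fold higher number from compound 3 to compound 4 (0.30 log units; within the scatter), and this step on the urea-linked core closely matches the earlier one on the thiourea-linked core: the same change on two cores in this assay, a 1.9-fold higher number (0.27 log units; within the scatter) from compound 1 to compound 2 and a 2.0-fold higher number (0.30 log units; within the scatter) from compound 3 to compound 4, 1.1-fold (0.03 log units) apart, within the scatter of two such steps

For these two cores, then, the change carried over at much the same size, and the step on one core was a fair guide to the step on the other. This does not show that the two dichlorophenyl patterns truly differ in this assay, as each step lies within the scatter, and two cores with a single change cannot show that the agreement would hold on other cores or for larger steps.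

Going by these compounds, it remains open how the number would move with an unsubstituted phenyl, a trifluoromethylphenyl or an amine in place of the dichlorophenyl group. On these data alone, whether the two cores would also agree for such groups is equally open.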